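The compounds below may be only part of what the source reports. "The series", "measured", "known", "first", "only" and "open" are said of these compounds alone.

Of the compounds shown here, two built on one shared core have been tested in a functional assay on MCF7 cells (Homo sapiens) for antiproliferative activity, read by MTT assay, with a stated time of 72 h; on this read-out lower numbers stand for stronger inhibition and higher numbers for weaker inhibition. Compound 1 `CCOC(=O)c1oc2ccc(NS(=O)(=O)c3ccccc3C)cc2c1C` gives 105000 nM. Compound 2 `CCOC(=O)c1oc2ccc(NS(=O)(=O)c3cccc(C(F)(F)F)c3)cc2c1C` gives 51400 nM, the lowest of the two numbers, and its gap to compound 1 lies beyond the scatter. Compound 3 `CCOC(=O)c1oc2ccc(NS(=O)(=O)c3cccc([N+](=O)[O-])c3)cc2c1C` has not yet been measured. It differs from compound 2 by nitro in place of trifluoromethyl on an aromatic carbon. Within the data shown here, no measured step shows what such a swap does here, so the expected step from compound 2 to compound 3 is a 1.2-fold higher number from compound 2 to compound 3 (0.07 log units; within the scatter), nothing beyond the scatter in either direction. Compound 3 is estimated at 60000 nM, within 20000 nM to 180000 nM.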

Compound 3, half-maximal inhibitory concentration: 74800 nM
The estimate for compound 3 lay 1.2-fold (0.10 log units) below the measured number; low and high end bracket the measured number.
By their numbers in this assay, from the lowest: compounds 2, 3 and 1 (each within the scatter of the next, the first and the last beyond it).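

In this assay the swap of trifluoromethyl for nitro on this aromatic carbon gives a 1.5-fold higher number from compound 2 to compound 3 (0.16 log units; within the scatter) and so separates the two groups by no more than repeat measurements would. Putting 3-nitrophenyl in place of 2-methylphenyl on the sulfonyl sulfur gives a 1.4-fold lower number from compound 1 to compound 3 (0.15 log units; within the scatter) and likewise stays inside that scatter. Nothing available here explains either small step.

On these data alone, whether an amine or a carboxylic acid on this aromatic carbon would shift the number beyond the scatter remains open. So does the effect of changing the ethyl ester on the shared core.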